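The compounds below may be only part of what the source reports. "The series", "measured", "known", "first", "only" and "open" are said of these compounds alone.

Working notes on the sulfonamide series.

Compound 1 `CNS(=O)(=O)Cc1noc2ccc(Cl)cc12` and compound 2 `CN(C)S(=O)(=O)Cc1noc2ccc(Cl)cc12` share one core; compound 3 `NS(=O)(=O)Cc1noc2ccc(Br)cc12` and the unmeasured compound 4 `CNS(=O)(=O)Cc1noc2ccc(Br)cc12` share another. The difference between the two cores is not broken down here. In a functional assay on the whole organism (strain STD-dd) with Mus musculus as the target, in the maximal electroshock model, with a stated time of 2 h (a higher number here means that more compound is needed for the effect, a lower number that less compound is needed), compound 1 gives 20 mg/kg, compound 2 gives 57 mg/kg and compound 3 gives 14 mg/kg. The step of a 2.9-fold higher number from compound 1 to compound 2 (0.45 log units; beyond the scatter) goes with methyl in place of hydrogen on a sulfonamide nitrogen. Among the measured compounds shown here, compound 4 carries the same kind of change, (methyl in place of hydrogen on a sulfonamide nitrogen), but the surroundings differ: in the first pair the nitrogen also carries a saturated chain carbon, in the second its only other neighbour is the sulfonyl sulfur. Starting from compound 3 and resting on the measured step from compound 1 to compound 2, a step of similar direction but uncertain size is expected, a 2.0-fold higher number from compound 3 to compound 4 (0.30 log units; within the scatter), the change lying beyond the scatter there. Compound 4 is therefore estimated at 28 mg/kg, between 14 mg/kg and 56 mg/kg.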

Compound 4, dose for half-maximal effect: 15 mg/kg
Estimate against measurement, compound 4: 1.9-fold (0.27 log units) above; the measured number falls inside the stated range.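

In this assay, methyl in place of hydrogen on a sulfonamide nitrogen goes with a 1.1-fold higher number from compound 3 to compound 4 (0.03 log units; within the scatter), and the two readings of this change cannot be told apart: the same change on two cores in this assay, a 2.9-fold higher number (0.45 log units; beyond the scatter) from compound 1 to compound 2 and a 1.1-fold higher number (0.03 log units; within the scatter) from compound 3 to compound 4, 2.7-fold (0.42 log units) apart, within the scatter of two such steps. This gives no sign that the core alters the change, but two pairs do not show that its size carries over, since only the first step lies beyond the scatter and the nitrogen has different surroundings in each pair. Bromo in place of chloro on an aromatic carbon goes with a 1.3-fold lower number from compound 1 to compound 4 (0.12 log units; within the scatter).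

Open remain a second methyl on the sulfonamide nitrogen of the bromo compounds and an ethyl or longer chain there. Also open, from the compounds shown here alone, is a fluoro group in place of the halogen.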